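Iodo in Place of Ethyl: From Compound 3 to Compound 4

A few compounds are considered here, and "the series" means these few. Any claim that something is new, unique, unknown or untested is made for them only; others in the source may bear on it.

Three compounds have so far been tested in a functional assay on the whole organism for displacement of a labelled ligand, with Rattus norvegicus as the target, at a dose of 3.2 mg/kg by the subcutaneous route; on this read-out higher numbers stand for more inhibition at the one dose given (going by the name of the read-out) and lower numbers for less inhibition:

compound 1 `C/C=C(\CC)Oc1cc(C)nc(Oc2c(C)cc(C)cc2C)c1C` gives 75%
compound 2 `CCC(CC)Oc1cc(C)nc(Oc2c(C)cc(C)cc2C)c1N` gives 78%
compound 3 `CCc1cc(C)c(Oc2nc(C)cc(OC(CC)CC)c2C)c(C)c1` gives 55%

Compound 3 stands lowest of the three. Compound 1 and compound 2 each lie above it, both gaps beyond the usual scatter of repeated measurements. Compound 1 and compound 2 each differ from compound 3 in more than one place, so neither pair isolates a single structural change.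

Compound 4 `CCC(CC)Oc1cc(C)nc(Oc2c(C)cc(I)cc2C)c1C` is the next compound. Relative to compound 3 the change is iodo in place of ethyl on an aromatic carbon.

Within the data shown here, no measured pair shows this exact exchange, so the size of the step is uncertain. Compound 3 already has the lowest number of the three, and the higher readings of compound 1 and compound 2 show that higher inhibition in this assay is reached on the shared core. A modest rise is expected, of a size that could fall within or just beyond the scatter: the step from compound 3 to compound 4 is estimated as a number 10 percentage points higher from compound 3 to compound 4 (within the scatter). Compound 4 is thus expected to give about 65%, with a plausible range from 42% to 85%.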

Compound 4, a percentage reported as inhibition, in the whole organism at one dose (the size of the read-out at that dose, not a potency): 27%
For compound 4 the middle estimate is 38 percentage points above the measured one; the whole stated range lies above it.
By their numbers in this assay, from the lowest: compound 4; then compound 3; then compounds 1 and 2 (each within the scatter of the next).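

Iodo in place of ethyl on this aromatic carbon gives, in this assay, a number 28 percentage points lower from compound 3 to compound 4 (beyond the scatter). Among these compounds, this is the first comparison that differs in one place only, and it shows that the group on this carbon, para to a large group and meta to two methyl groups, can by itself change the reading at this dose. Nothing measured here says why the number falls.

The compounds shown leave open whether the trend belongs to iodo alone, as they do not tell how chloro, methoxy or a longer chain such as propyl would read on this same carbon. From the compounds shown here alone, the read-out also gives the size of the inhibition at one dose rather than a potency, so how the two compounds would compare at other doses remains open.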